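Compound 1 to compound 4: a change of configuration only

The source may report more compounds than this note shows. Statements on the series, on what has been measured and on what is new or still open speak of the compounds shown alone.

For the measured compounds named here, in an ADME assay on HFF cells (Homo sapiens) for cytotoxicity, read by neutral red uptake (a lower number here means that less compound is tolerated, a higher number that more compound is tolerated), compound 1 (`Nc1ncnc2c1ncn2/C=C1\C[C@H]1[C@H](O)CO`) gives 194000 nM, the only actual number. Compound 2 (`Nc1nc2c(ncn2/C=C2\C[C@H]2[C@H](O)CO)c(=O)[nH]1`) reads > 300000 nM, which is a limit. Compound 3 (`Nc1nc2c(ncn2/C=C2/C[C@@H]2[C@H](O)CO)c(=O)[nH]1`) reads > 300000 nM, also a limit. Compound 4 (`Nc1ncnc2c1ncn2/C=C1/C[C@@H]1[C@@H](O)CO`) is the configurational counterpart of compound 1: the two compounds have the same atoms and bonds and differ only in configuration as drawn: 3 of 3 stereo elements differ; a stereocentre at a saturated ring carbon is drawn R in compound 1 and S in compound 4; a stereocentre at a saturated chain carbon is drawn S in compound 1 and R in compound 4; a double bond is drawn E in compound 1 and Z in compound 4. Going by the values given here, the only measured step that bears on this change is a step that the two limits leave unreadable from compound 2 to compound 3, which rests on the fact that compounds 2 and 3 differ only in the configuration as drawn and on (the limit of > 300000 nM in this assay, at which 2 of the 3 values shown sit). It offers no size to carry over. The expectation therefore stays close to compound 1 at 194000 nM, with no step beyond the scatter expected in either direction. The expected change is a 1.1-fold higher number from compound 1 to compound 4 (0.05 log units; within the scatter). Compound 4 is estimated at 220000 nM, with an expected range of 110000 nM to 300000 nM.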

Compound 4, half-maximal cytotoxic concentration: > 300000 nM
Compound 4: only a limit was reported (the forecaster's own chance of this, stated with the estimate: 40%); at least 1.3-fold (0.13 log units) between middle value and limit.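

Unlike the earlier pair of limits, this change gives a readable floor in this assay: an at least 1.5-fold higher number from compound 1 to compound 4 (0.18 log units; that floor lies within the scatter). Compound 4 reads > 300000 nM, which is a limit, so the step has no upper size and its floor does not separate the two compounds beyond the scatter. The series now crowds against one ceiling: the limit of > 300000 nM in this assay, at which 3 of the 4 values shown sit.

Open, going by these compounds, is which single stereo element, taken alone, would move the number, and where the true value of compound 4 lies. Also open, on these data alone, is how a compound carrying a longer chain or a carboxylic acid would read in this assay.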